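The source may hold more compounds than are shown below. What is called first, only, known or untested is meant among the compounds shown, and "the series" means these compounds.

Measured compounds:
- compound 1 `O=C(Nc1nn(-c2ccccc2)c(=O)c2ccccc12)c1ccc(Cl)cc1`: in an assay on CHO cells for displacement of a labelled ligand from adenosine receptor A1 (Homo sapiens), tested at 10 uM (a lower number here means less inhibition, a higher number more inhibition at the concentration tested (going by the name of the read-out)), compound 1 gives 26%
- compound 2 `COc1ccccc1NC(=O)Nc1nn(-c2ccccc2)c(=O)c2ccccc12`: in this assay compound 2 gives 0%

Compound 2 stands lowest of the two numbers; its nearest neighbour is compound 1, and the step of a number 26 percentage points lower from compound 1 to compound 2 (beyond the scatter) separates them. Compound 3 `O=C(Nc1nn(-c2ccccc2)c(=O)c2ccccc12)c1ccco1` differs from compound 2 by furan-2-yl in place of (2-methoxyphenyl)amino on a carbonyl carbon. Among the compounds with values here, the one step that bears on this is a number 26 percentage points lower from compound 1 to compound 2 (beyond the scatter), which describes the reverse move, from a carbon-linked aromatic ring to the group that now leaves; undoing a change of that kind on a smaller aromatic ring is expected to raise inhibition modestly, as a number 15 percentage points higher from compound 2 to compound 3 (beyond the scatter). Compound 3 is therefore estimated at 15%, within 0% to 35%.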

Compound 3, a percentage reported as inhibition, at one concentration (the size of the read-out at that concentration, not a potency): 23%
Compound 3: middle estimate off by 8 percentage points, on the low side; low and high end bracket the measured number.
By their numbers in this assay, from the lowest: compound 2; then compounds 3 and 1 (each within the scatter of the next).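

Putting furan-2-yl in place of (2-methoxyphenyl)amino on the carbonyl carbon gives a number 23 percentage points higher from compound 2 to compound 3 (beyond the scatter) in this assay, so the loss seen with the earlier change does not depend on 4-chlorophenyl alone. Furan-2-yl in place of 4-chlorophenyl gives a number 3 percentage points lower from compound 1 to compound 3 (within the scatter), so these two carbon-linked rings cannot be told apart here. No available data explain these differences.

On these data alone, it remains open whether the low value of compound 2 follows from the linking nitrogen or from the methoxy group. A plain phenylamino group or a carbon-linked cyclohexyl group would help separate these.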